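The compounds below may be only part of what the source reports. "The series", "measured", "known", "first", "only" and "open" are said of these compounds alone.

Series notes. Compound 1 `CC(C)(C)CCC1([C@H](O)/C=C/[C@H]2COC(=O)N2CCSc2nc(C(=O)O)cs2)CCC1` and compound 2 `O=C(O)c1csc(SCCN2C(=O)OC[C@@H]2/C=C/[C@@H](O)C2(CCCCF)CCC2)n1` share one core and differ only on a saturated chain carbon, two bonds along the chain from a saturated ring carbon. In an assay on isolated protein for agonist activity at prostaglandin E2 receptor EP3 subtype (Homo sapiens) (on this read-out higher numbers stand for an effect only at larger amounts of compound and lower numbers for an effect already at smaller amounts), compound 1 gives 6.7 nM. In this assay, going by the values given here, compound 2 gives 10 nM, which places it at the top of the two numbers measured so far, with compound 1 the nearest; the gap between them is within the scatter. Among the compounds with values here, the one measured step reads a 1.5-fold higher number from compound 1 to compound 2 (0.17 log units; within the scatter). Compound 3 `O=C(O)c1csc(SCCN2C(=O)OC[C@@H]2/C=C/[C@@H](O)C2(CCc3ccccc3)CCC2)n1` carries phenyl in place of 2-fluoroethyl on a saturated chain carbon, two bonds along the chain from a saturated ring carbon. Within the data shown here, only the step from compound 1 to compound 2 bears on this change, and that swap at the same place left the number within the scatter; the phenyl entering compound 3 is a different group, so no direction can be read from it. The expected step is no change at the digits printed from compound 2 to compound 3 (within the scatter), not beyond the scatter. Compound 3 is expected to give an estimated 10 nM in this assay, with a range from 3 nM to 35 nM.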

Compound 3, half-maximal effective concentration: 27 nM
Compound 3: the middle estimate sits 2.7-fold (0.43 log units) below what was measured; low and high end bracket the measured number.
By their numbers in this assay, from the lowest: compounds 1 and 2 (each within the scatter of the next); then compound 3.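

In this assay, going by these compounds alone, phenyl gives the first change at this position that lies beyond the scatter: a 2.7-fold higher number from compound 2 to compound 3 (0.43 log units; beyond the scatter) and, against tert-butyl, a 4.0-fold higher number from compound 1 to compound 3 (0.61 log units; beyond the scatter), both modest. The position on the saturated chain carbon therefore does not take every swap without effect, although the swap from tert-butyl to 2-fluoroethyl left the number within the scatter. Nothing measured here explains the higher number with phenyl.

As far as these compounds go, it remains open whether the higher number belongs to the aromatic ring as such, which a cyclohexyl group at the same place would test against a saturated ring. Also open, from the compounds shown here alone, is how an amine or a hydroxyl on the phenyl, or a longer chain carrying it, would read in this assay.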